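From 2-chlorophenyl to 4-fluorophenyl: how big a step?

The source may hold more compounds than are shown below. What is called first, only, known or untested is meant among the compounds shown, and "the series" means these compounds.

- Compound 1 `O=C1/C(=C/c2ccccc2F)CN(Cc2cn(Cc3ccccc3F)nn2)C/C1=C\c1ccccc1F`: 10600 nM
- Compound 2 `O=C1/C(=C/c2ccccc2F)CN(Cc2cn(Cc3cccc(Cl)c3)nn2)C/C1=C\c1ccccc1F`: 4300 nM
- Compound 3 `O=C1/C(=C/c2ccccc2F)CN(Cc2cn(Cc3ccccc3Cl)nn2)C/C1=C\c1ccccc1F`: 7500 nM

In a functional assay on DU-145 cells (Homo sapiens) for cytotoxicity, read by MTT assay, with a stated time of 24 h (on this read-out lower numbers stand for stronger inhibition and higher numbers for weaker inhibition), compound 3 gives 7500 nM, a number within the scatter of both other compounds. Compound 4 `O=C1/C(=C/c2ccccc2F)CN(Cc2cn(Cc3ccc(F)cc3)nn2)C/C1=C\c1ccccc1F` changes one group: 4-fluorophenyl in place of 2-chlorophenyl on a saturated chain carbon bound to an aromatic nitrogen. It carries 4-fluorophenyl in place of 2-chlorophenyl on a saturated chain carbon bound to an aromatic nitrogen. Among the compounds with values here, no measured compound carries 4-fluorophenyl, so the evidence is indirect. Two similar swaps stayed within the scatter: a 1.4-fold lower number from compound 1 to compound 3 (0.15 log units; within the scatter) and a 1.7-fold higher number from compound 2 to compound 3 (0.24 log units; within the scatter). The largest, a 2.5-fold lower number from compound 1 to compound 2 (0.39 log units; beyond the scatter), was modest. On that basis, no step beyond the scatter is expected in this assay, and the estimated change is a 1.1-fold lower number from compound 3 to compound 4 (0.03 log units; within the scatter). For compound 4 the expected value is 7000 nM, with an estimated range from 3000 nM to 15000 nM.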

Compound 4, half-maximal inhibitory concentration: 8700 nM
Compound 4: middle estimate off by 1.2-fold (0.09 log units), on the low side; measured number inside the range.
By their numbers in this assay, from the lowest: compounds 2, 3, 4 and 1 (each within the scatter of the next, the first and the last beyond it).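

In this assay the 4-fluorophenyl group stays within the scatter of two earlier groups, with a 1.2-fold higher number from compound 3 to compound 4 (0.06 log units; within the scatter) and a 1.2-fold lower number from compound 1 to compound 4 (0.09 log units; within the scatter). Swapping 2-fluorophenyl for 4-fluorophenyl therefore gives no step beyond the scatter at this position. The 3-chlorophenyl group of compound 2 alone stands apart from the new group, with a 2.0-fold higher number from compound 2 to compound 4 (0.31 log units; beyond the scatter), a modest step.

No measurement here offers an explanation for these numbers. On these data alone, whether an amine, a carboxylic acid or a longer chain in place of these phenyl groups would give a larger step remains open.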